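One group changes on the way to compound 4

This account rests on a few compounds, and the source may have more. Where it says the series, first, only, none or still open, it means among the compounds named here.

In a physicochemical assay for lipophilicity, read by HPLC, at pH 7.5 (a lower number here means a more polar compound, a higher number a more lipophilic compound), compound 1 `CC[C@@H](Nc1c(C#N)c(-c2ccc(-c3ccc(OC)cc3)cc2)nc2cnccc12)C(N)=O` reads 2.7 and compound 2 `CC[C@@H](Nc1c(C#N)c(-c2ccc(-c3cccc(CO)c3)cc2)nc2cnccc12)C(N)=O` reads 2 while compound 3 `CC[C@@H](Nc1c(C#N)c(-c2ccc(-c3cccnc3C)cc2)nc2cnccc12)C(N)=O` reads 1.9 on the same scale. Compound 3 stands under compound 1 with a number 0.80 log units lower from compound 1 to compound 3 (beyond the scatter) as the gap. Against compound 2 there is a number 0.10 log units lower from compound 2 to compound 3 (within the scatter) so those two cannot be told apart.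

Still unmeasured is compound 4 `CC[C@@H](Nc1c(C#N)c(-c2ccc(-c3ccccc3NC)cc2)nc2cnccc12)C(N)=O` and the change 2-(methylamino)phenyl in place of 2-methylpyridin-3-yl on an aromatic carbon puts 2-(methylamino)phenyl in place of 2-methylpyridin-3-yl on an aromatic carbon. Within the data shown here, no measured step makes this exact exchange, so the evidence is indirect. The gap between compound 1 and compound 3 is the closest guide, since it links a phenyl group to the same 2-methylpyridin-3-yl that now leaves. Read backwards, it points to a higher number. A caution comes from a number 0.70 log units lower from compound 1 to compound 2 (beyond the scatter) as a step that also ends on a ring of carbon only, so such a ring does not by itself restore the number of compound 1. A rise of similar size, slightly smaller than the gap, is therefore expected. The estimated move is a number 0.60 log units higher from compound 3 to compound 4 (beyond the scatter) in this assay overall. The estimate for compound 4 is 2.5 with an expected range from 2.1 to 2.9 in this measurement.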

Compound 4, distribution coefficient: 2.5
For compound 4 middle estimate and measured number coincide at the digits printed, within the range that was stated.
By their numbers in this assay, from the lowest: compounds 3 and 2 (each within the scatter of the next); then compounds 4 and 1 (each within the scatter of the next).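

Among these compounds, at this place, on an aromatic carbon para to a large group, the exchange of 2-methylpyridin-3-yl for 2-(methylamino)phenyl gives (a number 0.60 log units higher from compound 3 to compound 4 (beyond the scatter)) in this assay, the first measured step at this place that starts from the pyridine-type ring and ends on a ring of carbon only with a nitrogen-bearing group on it. The step (a number 0.50 log units higher from compound 2 to compound 4 (beyond the scatter)) joins two rings of carbon only, which shows that the number at this place depends on what the ring carries and not only on whether the ring holds a nitrogen atom. The step (a number 0.20 log units lower from compound 1 to compound 4 (within the scatter)) means that these two cannot be told apart on this scale, even though 2-(methylamino)phenyl and 4-methoxyphenyl are different groups.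

No measurement at hand offers an explanation for any of these steps. As far as these compounds go, the step from compound 3 to compound 4 changes the ring and its attached group together, and their shares remain open; a plain phenyl, a 2-methylphenyl or a 2-aminophenyl at this place would help to separate them.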